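The compounds below may be only part of what the source reports. "The series", "measured", "known", "first", "only" and "open" are said of these compounds alone.

Measured so far:
- compound 1, `Cc1c(OCCCCOc2ccccc2C(=O)O)ccc(C(=O)CC2CCCC2)c1C`: 2580 nM
- compound 2, `Cc1c(OCCCCOc2ccc(F)c(C(=O)O)c2)ccc(C(=O)CC2CCCC2)c1C`: "not determined" (no result reported)

Going by the values given here, compound 1 is the only compound here with a number. In an assay on HEK293 cells for positive allosteric modulation of metabotropic glutamate receptor 2 (Rattus norvegicus), read by thallium flux, with a stated time of 2.5 min (on this read-out lower numbers stand for an effect already at smaller amounts and higher numbers for an effect only at larger amounts of compound), compound 1 gives 2580 nM, and compound 2 has no value to set beside it, so nothing can be said about how the two compare.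

Compound 3, `Cc1c(OCCCCOc2ccccc2C(=O)O)ccc(C(=O)CC(C)C)c1C`, differs from compound 1 in one place: isopropyl in place of cyclopentyl on a saturated chain carbon bound to a carbonyl carbon. Among the compounds with values here, no pair of measured compounds shows what such a change does, so the expectation rests on compound 1 alone and on the size of the group that is swapped.

The step is expected to run toward weaker activity, that is toward a higher number, with a size of about a 2.3-fold higher number from compound 1 to compound 3 (0.37 log units; beyond the scatter), somewhat beyond the usual scatter but not large. Compound 3 is therefore estimated at 6000 nM, with a likely range from 2000 nM to 18000 nM.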

Compound 3, half-maximal effective concentration: 976 nM
Estimate against measurement, compound 3: 6.1-fold (0.79 log units) above, outside the stated range (below it).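

This first measured change at this place, on a saturated chain carbon bound to a carbonyl carbon, shows that the cyclopentyl ring is not needed for activity. In this assay, isopropyl in place of cyclopentyl gives a 2.6-fold lower number from compound 1 to compound 3 (0.42 log units; beyond the scatter), a modest change. Here the group with 3 heavy atoms and no ring therefore acts at smaller amounts of compound than the group with 5 heavy atoms and a ring, and no measurement shown gives a reason for this.

On these data alone, whether methyl, with fewer carbons still, would lower the number further remains open. So does what a cyclopropyl ring, a longer chain such as n-butyl, or an amine would do at this place.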